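The compounds below may be only part of what the source reports. "The series", "measured", "known", "first", "only" and "open" are said of these compounds alone.

Measured compounds:
compound 1 `Cc1cc(C(=O)O)ccc1OCCCCOc1ccc(C(=O)CC(C)C)c(O)c1C`, 42.1%
compound 2 `Cc1c(OCCCCOc2ccccc2C(=O)O)ccc(C(=O)CC2CCCC2)c1C`, 28%
compound 3 `COC(=O)c1ccc(OCCCCOc2ccc(C(=O)CC3CCCC3)c(C)c2C)cc1`, 24.2%

In an assay on HEK293 cells for positive allosteric modulation of metabotropic glutamate receptor 3 (Rattus norvegicus), read by thallium flux, with a stated time of 2.5 min (on this read-out higher numbers stand for larger maximal responses and lower numbers for smaller maximal responses), compound 1 gives the highest of the three numbers; compound 2 lies 28% and compound 3 lies 24.2%, both beyond the scatter from compound 1. Among the measured compounds shown here, the one measured step, a number 3.8 percentage points lower from compound 2 to compound 3 (within the scatter), concerns the acid-bearing ring at the far end of the chain but changes a carboxy group into a methoxycarbonyl group, and it stays within the scatter.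

Compound 4 `Cc1c(OCCCCOc2ccc(C(=O)O)cc2F)ccc(C(=O)CC(C)C)c1O` differs from compound 1 by fluoro in place of methyl on an aromatic carbon, on an aromatic carbon of a six-membered aromatic ring of carbon only, ortho to a large group and meta to a carboxy group. For the measured compounds named here, no measured step exchanges a methyl for a fluoro, so nothing here speaks for a shift in either direction. The step from compound 1 to compound 4 is therefore expected to be a number 4.1 percentage points lower from compound 1 to compound 4 (within the scatter), not beyond the scatter. Compound 4 is estimated at 38%, between 22% and 54%.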

Compound 4, largest response reached (reported as percent of maximum), in percent of the reference or control that the assay uses: 67.7%
The estimate for compound 4 lay 29.7 percentage points below the measured number; the measured number lies above the stated range.
By their numbers in this assay, from the lowest: compounds 3 and 2 (each within the scatter of the next); then compound 1; then compound 4.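

In this assay, exchanging one small group for another on the acid-bearing ring is not a neutral change: fluoro in place of methyl gives a number 25.6 percentage points higher from compound 1 to compound 4 (beyond the scatter). Among the compounds shown here, the earlier compounds had no step at this place, ortho to a large group and meta to a carboxy group, so this is the first sign that the group here can shift the maximal response. Both groups count one heavy atom and no hydrogen-bond donors or acceptors, and nothing measured here gives a reason for the rise.

From the compounds shown here alone, with a single pair, it remains open whether the rise comes from gaining fluoro or from losing methyl; a chloro group or a plain hydrogen at the same place would help separate the two. Going by these compounds, whether the same exchange would raise the number on a different compound, such as compound 2, also remains open.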